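A few compounds are considered here, and "the series" means these few. Any claim that something is new, unique, unknown or untested is made for them only; others in the source may bear on it.

Measured in an ADME assay on J774 cells (Mus musculus) for cytotoxicity; on this read-out lower numbers stand for an effect already at smaller amounts and higher numbers for an effect only at larger amounts of compound:
compound 1 `CCCCCCC/C=C/c1c(C)[nH]c2ccccc2c1=O`: 28000 nM
compound 2 `CCCCCC/C=C\Cc1c(C)[nH]c2ccccc2c1=O`: 48500 nM

Compound 1 and compound 2 lie within the usual scatter of each other, so these two numbers show no order. Compound 3 `Cc1[nH]c2ccccc2c(=O)c1/C=C/c1ccc(O)cc1` has not yet been measured. Its difference from compound 1 is 4-hydroxyphenyl in place of heptyl on a double-bonded chain carbon bound to a double-bonded chain carbon, which places 4-hydroxyphenyl in place of heptyl on a double-bonded chain carbon bound to a double-bonded chain carbon.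

Among the compounds with values here, no measured pair covers this change, so the expectation rests on the structural change alone and is uncertain. A modest move to a higher number in this assay is expected, though a result within the scatter remains possible. The estimated size is a 2.1-fold higher number from compound 1 to compound 3 (0.33 log units; beyond the scatter). For compound 3 the expected value is 60000 nM, with an estimated range of 20000 nM to 170000 nM.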

Compound 3, half-maximal effective concentration in the J774 assay: > 36100 nM
Compound 3 ended at the assay's limit; the forecaster's own chance of this, stated with the estimate: 25%; the middle value does not contradict the limit.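

In the J774 assay, 4-hydroxyphenyl in place of heptyl on a double-bonded chain carbon bound to a double-bonded chain carbon gives an at least 1.2-fold higher number from compound 1 to compound 3 (0.11 log units; that floor lies within the scatter), a floor and not a measured size, as the value of compound 3 is a limit: the limit of > 36100 nM in the J774 assay, at which 1 of the 3 values shown sits.

In a physicochemical assay for solubility, read by HPLC, at pH 7.4 (on this read-out higher numbers stand for higher solubility and lower numbers for lower solubility), compound 1 gives < 2000 nM, which is a limit. In the physicochemical assay compound 3 gives > 20000 nM, which is also a limit. In the physicochemical assay the same change gives an at least 10-fold higher number from compound 1 to compound 3 (1.00 log units; beyond the scatter), which is beyond the scatter, though both compounds carry limits here: the limit of < 2000 nM in the physicochemical assay, at which 1 of the 2 values shown sits, and the limit of > 20000 nM in the physicochemical assay, at which 1 of the 2 values shown sits.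

At this place, then, a group with an aromatic ring can replace the chain with no move to a lower number in the J774 assay, while the same change clearly raises the number in the physicochemical assay.

From the compounds shown here alone, the true size of both steps stays open, as does whether the ring or its hydroxyl accounts for them. A plain phenyl at this place would separate the two.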